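A few compounds are considered here, and "the series" means these few. Any claim that something is new, unique, unknown or untested is made for them only; others in the source may bear on it.

Of the compounds shown here, three from this series have been measured. Compound 1 `Cc1cc(C(=O)c2ccccc2)ccc1OCC(=O)Nc1nc(-c2ccccc2)cs1` gives 24000 nM in a functional assay on Ehrlich cells (Mus musculus) for cytotoxicity, read by MTT assay, with a stated time of 48 h; a higher number here means a weaker inhibitor, a lower number a stronger inhibitor. Compound 2 `COc1ccc(-c2csc(NC(=O)COc3ccc(C(=O)c4ccccc4)cc3C)n2)cc1` gives 28400 nM in this assay, and compound 3 `Cc1cc(C(=O)c2ccccc2)cc(C)c1OCC(=O)Nc1nc(-c2ccccc2)cs1` gives 22700 nM. Compound 3 carries the lowest of the three numbers, but its gaps to compound 1 and to compound 2 both lie within the scatter. Compound 4 `COc1ccc(-c2csc(NC(=O)COc3c(C)cc(C(=O)c4ccccc4)cc3C)n2)cc1` differs from compound 3 by methoxy in place of hydrogen on an aromatic carbon. The same change has already been seen once, with a 1.2-fold higher number from compound 1 to compound 2 (0.07 log units; within the scatter), and the other step, a 1.1-fold lower number from compound 1 to compound 3 (0.02 log units; within the scatter), was likewise within the scatter. No shift beyond the scatter is therefore expected, and the estimated step is a 1.1-fold higher number from compound 3 to compound 4 (0.06 log units; within the scatter). Compound 4 is expected to give 26000 nM, with a range from 13000 nM to 52000 nM.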

Compound 4, half-maximal inhibitory concentration: 41200 nM
Compound 4: middle estimate off by 1.6-fold (0.20 log units), on the low side; low and high end bracket the measured number.
By their numbers in this assay, from the lowest: compounds 3, 1, 2 and 4 (each within the scatter of the next).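

In this assay, the change from phenyl to 4-methoxyphenyl can now be read on a second core, giving a 1.8-fold higher number from compound 3 to compound 4 (0.26 log units; within the scatter), so methoxy at this position has not moved the number beyond the scatter on either core: the same change on two cores in this assay, a 1.2-fold higher number (0.07 log units; within the scatter) from compound 1 to compound 2 and a 1.8-fold higher number (0.26 log units; within the scatter) from compound 3 to compound 4, 1.5-fold (0.19 log units) apart, within the scatter of two such steps

The methyl change can also now be read on a core carrying the methoxy, giving a 1.5-fold higher number from compound 2 to compound 4 (0.16 log units; within the scatter), which again stays within the scatter: the same change on two cores in this assay, a 1.1-fold lower number (0.02 log units; within the scatter) from compound 1 to compound 3 and a 1.5-fold higher number (0.16 log units; within the scatter) from compound 2 to compound 4, 1.5-fold (0.19 log units) apart, within the scatter of two such steps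

With only hydrogen and methoxy shown at this position, it remains open whether another group there, such as an amine or a carboxylic acid, would move the number beyond the scatter.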